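Dichlorophenyl to Naphthyl on the Benzylic Arm

A few compounds are considered here, and "the series" means these few. Any claim that something is new, unique, unknown or untested is made for them only; others in the source may bear on it.

compound 1 `CN(C(=O)c1cc(C(F)(F)F)cc(C(F)(F)F)c1)N(CCC(=O)N[C@@H]1CCCCNC1=O)Cc1cc(Br)c(Br)s1`: 19.5 nM
compound 2 `CN(C(=O)c1cc(C(F)(F)F)cc(C(F)(F)F)c1)N(CCC(=O)N[C@@H]1CCCCNC1=O)Cc1ccc(Cl)c(Cl)c1`: 5.5 nM

In an assay on CHO cells for binding affinity to Substance-K receptor (Homo sapiens), read by radioligand binding (on this read-out lower numbers stand for stronger inhibition and higher numbers for weaker inhibition), compound 1 gives 19.5 nM, and compound 2 gives 5.5 nM, the lower of the two numbers. Among the compounds with values here, the single measured step, a 3.5-fold lower number from compound 1 to compound 2 (0.55 log units; beyond the scatter), altered the same aryl group that is changed next. Compound 3 `CN(C(=O)c1cc(C(F)(F)F)cc(C(F)(F)F)c1)N(CCC(=O)N[C@@H]1CCCCNC1=O)Cc1ccc2ccccc2c1` carries naphthalen-2-yl in place of 3,4-dichlorophenyl on a saturated chain carbon bound to an amine nitrogen. Within the data shown here, no measured step covers a two-ring aryl group here, so the earlier step shows only that this position can shift the number. A modest rise is expected, a 2.7-fold higher number from compound 2 to compound 3 (0.44 log units; beyond the scatter). Compound 3 is estimated at 15 nM. The expected range for compound 3 runs from 4 nM to 60 nM.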

Compound 3, half-maximal inhibitory concentration: 55 nM
Compound 3: middle estimate off by 3.7-fold (0.56 log units), on the low side; measured number inside the range.
By their numbers in this assay, from the lowest: compound 2; then compound 1; then compound 3.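

In this assay the naphthalen-2-yl group gives the highest number of the three aryl groups on this saturated chain carbon bound to an amine nitrogen, with a 10-fold higher number from compound 2 to compound 3 (1.00 log units; beyond the scatter) and a 2.8-fold higher number from compound 1 to compound 3 (0.45 log units; beyond the scatter) as its two steps. Adding a second six-membered aromatic ring of carbon only therefore did not preserve the low number held by the 3,4-dichlorophenyl group in this series. Nothing available explains this rise. Still open, from the compounds shown here alone, is whether a single chlorophenyl, a methoxyphenyl or a pyridyl group on this arm would match 3,4-dichlorophenyl, and whether chlorine on the naphthalene would bring the number back down.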